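The compounds below may be only part of what the source reports. "The series", "measured", "known", "first", "only" and "open" are said of these compounds alone.

Compound 1 `N#C/C(=C\c1c(-c2ccccc2)[nH]c2ccccc12)C(=O)Nc1ccc(Cl)cc1` was examined in a functional assay on MT4 cells (Homo sapiens) for antiproliferative activity, read by MTT assay, with a stated time of 96 h (a higher number here means that more compound is needed for the effect, a lower number that less compound is needed), where compound 1 gives 1700 nM, the higher of the two numbers recorded for this series. Compound 2 `COc1ccc2[nH]c(-c3ccccc3)c(/C=C(\C#N)S(=O)(=O)c3ccccc3)c2c1` stands nearest to it, and in this assay compound 2 gives 1300 nM, a difference from compound 1 that falls within the scatter. Going by the values given here, compound 3 `N#C/C(=C\c1c[nH]c2ccccc12)S(=O)(=O)c1ccccc1` is the one case whose value is a limit of the assay rather than a number: in this assay compound 3 gives > 100000 nM, which is the limit of > 100000 nM in this assay, at which 1 of the 3 values shown sits.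

The step from compound 1 to compound 4 `COCCOC(=O)/C(C#N)=C/c1c(-c2ccccc2)[nH]c2ccccc12` changes (2-methoxyethoxy in place of (4-chlorophenyl)amino on a carbonyl carbon). Among the compounds with values here, no pair of measured compounds shows a step of this kind, so its size cannot be read from the data in hand. The expected step, a 2.1-fold higher number from compound 1 to compound 4 (0.31 log units; beyond the scatter), is toward a higher number, somewhat beyond the scatter but modest. Compound 4 is therefore estimated at 3500 nM in this assay, with a range from 900 nM to 15000 nM.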

Compound 4, half-maximal effective concentration: 1200 nM
Compound 4: the middle estimate sits 2.9-fold (0.46 log units) above what was measured, within the range that was stated.
By their numbers in this assay, from the lowest: compounds 4, 2 and 1 (each within the scatter of the next). At a limit, above all of these: compound 3.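

In this assay the new group on the carbonyl carbon gives a 1.4-fold lower number from compound 1 to compound 4 (0.15 log units; within the scatter) and so the (4-chlorophenyl)amino group, with its aromatic ring and its hydrogen-bond donor, can give way to the open 2-methoxyethoxy chain with no change beyond the scatter. Going by these compounds alone, this is the first step read at this place, and it shows that, for this pair, neither that ring nor the amide hydrogen of compound 1 is required for a number of this size. Nothing in the data in hand bears on why the two groups read alike.

Going by these compounds, what a carboxylic acid, a simple amine or a longer ether chain on the same carbonyl carbon would give remains open. Whether the same tolerance holds on the other cores shown also remains open.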